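Adding a nitro group to compound 3

A few compounds are considered here, and "the series" means these few. Any claim that something is new, unique, unknown or untested is made for them only; others in the source may bear on it.

In a functional assay on KB cells (Homo sapiens) for inhibition, read by MTT assay, with a stated time of 24 h, tested at 0.1 ug/mL (on this read-out lower numbers stand for less inhibition of growth and higher numbers for more inhibition of growth at the one concentration tested), compound 1 (`CC(=O)SCCC(CCCCC(=O)O)SC(C)=O`) gives 7.24% and compound 3 (`O=C(CCCCC1CCSS1)Nc1cccc(C(F)(F)F)c1`) gives 0.33%, so these two compounds lie within the scatter of each other. Compound 2 (`O=C(O)CCCCC(CCSC(=O)c1ccccc1)SC(=O)c1ccccc1`) is reported only as "not active" (no number reported), without a number. Compound 4 (`O=C(CCCCC1CCSS1)Nc1ccc([N+](=O)[O-])c(C(F)(F)F)c1`) differs from compound 3 by nitro in place of hydrogen on an aromatic carbon, ortho to a trifluoromethyl group and para to a large group. Within the data shown here, no measured pair shows this change, so nothing scales it directly. In this assay, the estimated step is a number 2.7 percentage points higher from compound 3 to compound 4 (within the scatter), expected to stay within the scatter. For compound 4 the expected value is 3%, with an estimated range of 0% to 13%.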

Compound 4, percent growth inhibition at one concentration: 4.5%
The estimate for compound 4 lay 1.5 percentage points below the measured number, and the stated range covers the measured number.
By their numbers in this assay, from the lowest: compounds 3, 4 and 1 (each within the scatter of the next).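

In this assay, the series now has its first measured step: nitro in place of hydrogen on an aromatic carbon, ortho to a trifluoromethyl group and para to a large group, gives a number 4.2 percentage points higher from compound 3 to compound 4 (within the scatter) at this position. On this single step, nitro at this position leaves the reading within the scatter of the hydrogen compound. No measurement available here bears on a cause for this result. Still open, on these data alone, is whether an amine or a nitrile at the same position would also stay within the scatter of compound 3.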